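The source may hold more compounds than are shown below. What is called first, only, known or untested is meant among the compounds shown, and "the series" means these compounds.

Of the compounds shown here, three have numbers so far in an ADME assay on L6 cells (Rattus norvegicus) for cytotoxicity; a lower number here means a stronger inhibitor, a higher number a weaker inhibitor. Compound 1 (`O=C(CN1CCN(c2ccc(Cl)cc2)CC1)N1CCN(c2ccc(Cl)cc2)CC1`) gives 116000 nM in this read-out, compound 2 (`COc1ccc(N2CCN(C(=O)Cn3cnc([N+](=O)[O-])n3)CC2)cc1`) gives 133000 nM and compound 3 (`O=C(Cn1ccnc1[N+](=O)[O-])N1CCN(c2ncccn2)CC1`) gives 280000 nM on the same scale. Compound 2 lies within the scatter of compound 1, so no order can be read between those two, while compound 3 carries a higher number than compound 2 by a gap beyond the scatter.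

Compound 4 (`O=C(Cn1cnc([N+](=O)[O-])n1)N1CCN(c2ccc(Cl)c(Cl)c2)CC1`) has no number yet. It differs from compound 2 by 3,4-dichlorophenyl in place of 4-methoxyphenyl on an amine nitrogen in a ring. Among the measured compounds shown here, no two measured compounds differ in only one place, so the series offers no direct measure of this exchange. For the measured compounds named here, the only measured compound carrying chlorine is compound 1, at 116000 nM in this assay, and one compound cannot separate the effect of chlorine from the other differences in its structure.

A small move toward a lower number is expected, near the edge of the scatter, and the expected step is a 1.9-fold lower number from compound 2 to compound 4 (0.28 log units; within the scatter) on this thin evidence. For compound 4 the estimated value is 70000 nM with an expected range from 25000 nM to 180000 nM in this assay.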

Compound 4, half-maximal inhibitory concentration: 108000 nM
Beside the measured number, compound 4's estimate is 1.5-fold (0.19 log units) below it; the range from low to high includes it.
By their numbers in this assay, from the lowest: compounds 4, 1 and 2 (each within the scatter of the next); then compound 3.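

In this assay, the series now has its first comparison that differs in one place: 3,4-dichlorophenyl in place of 4-methoxyphenyl on an amine nitrogen in a ring gives a 1.2-fold lower number from compound 2 to compound 4 (0.09 log units; within the scatter), so no order can be read between these two compounds. At this position, therefore, an exchange that removes the hydrogen-bond acceptor of the 4-methoxyphenyl group and brings in two chlorine atoms, with the heavy-atom count unchanged, leaves the read-out within the scatter. This holds for this one pair only, and no measured evidence bears on why the exchange produces no step beyond the scatter.

From the compounds shown here alone, whether this position stays as unresponsive with a very different group on the same nitrogen, such as a phenyl ring bearing a carboxylic acid or an aliphatic amine, remains open. Compound 3 differs from the others in more than one place, so its gap to compound 2 cannot be assigned to any single part of the structure, and the steps for the remaining pairs cannot be read.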